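The compounds below may be only part of what the source reports. "The series", "measured", "known", "first", "only" and "open" are said of these compounds alone.

Two compounds of the series have numbers in an assay on CHO cells for displacement of a labelled ligand from Substance-P receptor (Homo sapiens); a lower number here means a stronger inhibitor, a higher number a weaker inhibitor. Among the measured compounds shown here, compound 1 `COc1ccc(C(C)C)cc1[C@H]1COCC2(C1)OCCN[C@H]2c1ccc(F)cc1` gives 2.8 nM, and compound 2 `COc1ccc(C(F)(F)F)cc1[C@H]1COCC2(C1)OCCN[C@H]2c1ccc(F)cc1` gives 1.3 nM; the only measured step is a 2.2-fold lower number from compound 1 to compound 2 (0.33 log units; beyond the scatter). Compound 2 therefore holds the lower of the two numbers, with compound 1 the nearest at that modest distance.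

Compound 3 `COc1ccc(OC)c([C@H]2COCC3(C2)OCCN[C@H]3c2ccc(F)cc2)c1` differs from compound 2 by methoxy in place of trifluoromethyl on an aromatic carbon. For the measured compounds named here, the single measured step, a 2.2-fold lower number from compound 1 to compound 2 (0.33 log units; beyond the scatter), exchanged the group at this same position and moved this assay only modestly; it gives no direct reading on methoxy in place of trifluoromethyl, since no methoxy-bearing analogue at this position has a number yet. A step of similar modest size is expected, more likely toward a higher number than a lower one, because the trifluoromethyl of compound 2 gave the lowest number seen 1.3 nM. Compound 3 is estimated at 4 nM in this assay, within 1.5 nM to 12 nM. The step expected is a 3.1-fold higher number from compound 2 to compound 3 (0.49 log units; beyond the scatter).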

Compound 3, half-maximal inhibitory concentration: 16 nM
Estimate against measurement, compound 3: 4.0-fold (0.60 log units) below; measured number outside the range, above it.
By their numbers in this assay, from the lowest: compound 2; then compound 1; then compound 3.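

In this assay this position, para to a methoxy group, is more sensitive to the group it carries than the first pair suggested: a 12-fold higher number from compound 2 to compound 3 (1.09 log units; beyond the scatter) is a large step, against the modest 2.2-fold lower number from compound 1 to compound 2 (0.33 log units; beyond the scatter). The isopropyl analogue also lies on the lower side of methoxy, with a 5.7-fold higher number from compound 1 to compound 3 (0.76 log units; beyond the scatter), so compound 3 is the weakest of the three, and the order runs trifluoromethyl, isopropyl, methoxy, each step beyond the scatter. Nothing available accounts for this order, and the size of the methoxy penalty stands as an observation only.

Three groups cannot show which feature of the substituent tracks with the number, and a nitrile, a chlorine or an ethoxy at this position would test that further. On these data alone, whether the same order holds with a different group in place of the 4-fluorophenyl on the shared core also remains open.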